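Sulfonamide nitrogen substituents in the thiourea quinoline series

A few compounds are considered here, and "the series" means these few. Any claim that something is new, unique, unknown or untested is made for them only; others in the source may bear on it.

Compound 2 `N=C(N)NS(=O)(=O)c1ccc(N/C(S)=N\c2ccnc3cc(C(F)(F)F)ccc23)cc1` gives 33500 nM in a functional assay on HepG2 cells (Homo sapiens) for antiproliferative activity, read by sulforhodamine B assay, with a stated time of 48 h; a higher number here means a weaker inhibitor, a lower number a stronger inhibitor. Compound 1 `NS(=O)(=O)c1ccc(N/C(S)=N\c2ccnc3cc(C(F)(F)F)ccc23)cc1`, with hydrogen on the sulfonamide nitrogen, gives 52200 nM; the step of a 1.6-fold lower number from compound 1 to compound 2 (0.19 log units; within the scatter) is within the scatter, so the two cannot be ordered. Compound 3 `Cc1cc(C)nc(NS(=O)(=O)c2ccc(N/C(S)=N\c3ccnc4cc(C(F)(F)F)ccc34)cc2)n1` gives 72200 nM; the step of a 2.2-fold higher number from compound 2 to compound 3 (0.33 log units; beyond the scatter) is modest but beyond the scatter, whereas a 1.4-fold higher number from compound 1 to compound 3 (0.14 log units; within the scatter) stays within it. Compound 2 thus holds the low end of the three numbers, separated only from compound 3.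

Compound 4 `COc1cc(NS(=O)(=O)c2ccc(N/C(S)=N\c3ccnc4cc(C(F)(F)F)ccc34)cc2)nc(OC)n1` is not yet measured. Relative to compound 2 it carries a group of 10 heavy atoms (6 carbon, 2 nitrogen, 2 oxygen; one six-membered aromatic ring with 2 hetero atoms) in place of a group of 3 heavy atoms (1 carbon, 2 nitrogen; no ring), on a sulfonamide nitrogen. The measured step that bears on this is the one in which a six-membered aromatic ring with two hetero atoms likewise replaced the same group on the sulfonamide nitrogen, a 2.2-fold higher number from compound 2 to compound 3 (0.33 log units; beyond the scatter). Within the data shown here, nothing among the measured compounds separates the dimethoxy from the dimethyl substitution of that ring, so a step of similar size and direction is expected, a 1.9-fold higher number from compound 2 to compound 4 (0.29 log units; within the scatter). Compound 4 is therefore estimated at 65000 nM, with a range of 30000 nM to 140000 nM.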

Compound 4, half-maximal inhibitory concentration: 76700 nM
The estimate for compound 4 lay 1.2-fold (0.07 log units) below the measured number; the measured number falls inside the stated range.
By their numbers in this assay, from the lowest: compounds 2, 1, 3 and 4 (each within the scatter of the next, the first and the last beyond it).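

In this assay, a second ring group on the sulfonamide nitrogen again separates from the group in compound 2 (a 2.3-fold higher number from compound 2 to compound 4 (0.36 log units; beyond the scatter)), so both ring-bearing compounds now lie on the same side of compound 2. The exchange of 4,6-dimethylpyrimidin-2-yl for 2,6-dimethoxypyrimidin-4-yl gives no resolved difference (a 1.1-fold higher number from compound 3 to compound 4 (0.03 log units; within the scatter)), and 2,6-dimethoxypyrimidin-4-yl is not separated from hydrogen (a 1.5-fold higher number from compound 1 to compound 4 (0.17 log units; within the scatter)), so only the gaps from compound 2 to the two ring-bearing compounds exceed the scatter. Nothing available explains these steps.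

The compounds shown leave open whether a small group such as methyl or acetyl, or a longer chain ending in a carboxylic acid or an amine, on the sulfonamide nitrogen would move the number further in either direction. Going by these compounds, whether a phenyl ring without ring nitrogens would behave like the two pyrimidine groups also remains open.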